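The source may hold more compounds than are shown below. What is called first, only, known or untested is meant among the compounds shown, and "the series" means these compounds.

Compounds measured in a functional assay on HepG2 cells (Homo sapiens) for inhibition, read by MTT assay, with a stated time of 48 h; on this read-out higher numbers stand for weaker inhibition and lower numbers for stronger inhibition:
- compound 1, `COc1cc(/C=N/Nc2nc(-c3ccccc3)cs2)cc(Br)c1OC`, gives 68300 nM
- compound 2, `Fc1ccc(/C=N/Nc2nc(-c3cc(C(F)(F)F)cc(C(F)(F)F)c3)cs2)cc1F`, gives 16700 nM
- compound 3, `COc1cc(/C=N/Nc2nc(-c3ccc(F)c(F)c3)cs2)c(Br)c(Br)c1OC`, gives 49700 nM

On these three numbers compound 2 stands lowest, with compound 3 the nearest and compound 1 the furthest, both gaps lying beyond the usual scatter. The unmeasured compound 4, `COc1cc(/C=N/Nc2nc(-c3cc(C(F)(F)F)cc(C(F)(F)F)c3)cs2)cc(Br)c1OC`, differs from compound 2 in one place: 3-bromo-4,5-dimethoxyphenyl in place of 3,4-difluorophenyl on a carbon with a double bond to nitrogen. Among the compounds with values here, no pair of measured compounds isolates this change, so its size is uncertain. Since compound 1 and compound 3, which carry bromo and methoxy groups in that place, give higher numbers than compound 2 in this assay, compound 4 is expected to show a weakening step a 1.9-fold higher number from compound 2 to compound 4 (0.28 log units; within the scatter), beyond the scatter but modest. Compound 4 is therefore estimated at 32000 nM, between 11000 nM and 90000 nM.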

Compound 4, half-maximal inhibitory concentration: > 100000 nM
Compound 4 gave a limit, no number; the forecaster's own chance of this, stated with the estimate: 10%; middle value at least 3.1-fold (0.49 log units) from the limit.
By their numbers in this assay, from the lowest: compound 2; then compounds 3 and 1 (each within the scatter of the next). At a limit, above all of these: compound 4.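

Taken alone, the change from 3,4-difluorophenyl to 3-bromo-4,5-dimethoxyphenyl on a carbon with a double bond to nitrogen gives an at least 5.9-fold higher number from compound 2 to compound 4 (0.77 log units; beyond the scatter) in this assay. Within the data shown here, compounds 1, 2 and 3 differ in more than one place, so only this pair shows that this position alone can weaken inhibition beyond the scatter. Compound 4 gives a limit of the assay and not a number, so the step has a floor but no fixed size: the limit of > 100000 nM in this assay, at which 1 of the 4 values shown sits.

The compounds shown leave open whether the bromo group or the methoxy groups account for the step. From the compounds shown here alone, what an amine or a carboxylic acid in this place would give also remains open.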